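Urea Amine Swap and Cytotoxicity in HEL Cells

This account rests on a few compounds, and the source may have more. Where it says the series, first, only, none or still open, it means among the compounds named here.

Compound 1 `CCN(CC)C(=O)NCCCC(C)Nc1cc(OC)cc2cccnc12`: > 100000 nM
Compound 2 `COc1cc(NC(C)CCCNC(=O)N(C2CCCCC2)C2CCCCC2)c2ncccc2c1`: 27000 nM

In an ADME assay on HEL cells (Homo sapiens) for cytotoxicity (a higher number here means that more compound is tolerated, a lower number that less compound is tolerated), compound 1 gives > 100000 nM, which is a limit of the assay and not a number (the limit of > 100000 nM in this assay, at which 1 of the 2 values shown sits). Compound 2 gives 27000 nM in this assay. Compound 3 `COc1cc(NC(C)CCCNC(=O)NCC2CCCCC2)c2ncccc2c1` has not yet been measured there. It differs from compound 1 by (cyclohexylmethyl)amino in place of diethylamino on a carbonyl carbon. Going by the values given here, no step between measured compounds is available to guide the size of this change. The step of an at least 1.6-fold lower number from compound 1 to compound 3 (0.22 log units; that floor lies within the scatter) is expected to be modest and, if anything, toward less tolerated compound. Compound 3 is estimated at 60000 nM, with a likely range from 20000 nM to 150000 nM in this assay.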

Compound 3, half-maximal cytotoxic concentration: 74000 nM
Compound 3: middle estimate off by 1.2-fold (0.09 log units), on the low side; the range from low to high includes it.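

On a carbonyl carbon, (cyclohexylmethyl)amino in place of diethylamino gives an at least 1.3-fold lower number from compound 1 to compound 3 (0.13 log units; that floor lies within the scatter) in this assay. This swap, which brings in a six-membered ring and a hydrogen-bond donor, is therefore not shown to move the result beyond the scatter. Its full size cannot be read, because the value of compound 1 is a limit of the assay and not a number: the limit of > 100000 nM in this assay, at which 1 of the 3 values shown sits.

The compounds shown leave open whether the ring or the donor counts for more. They also leave open how a benzylamino or morpholino group on this carbonyl carbon would behave in this assay.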